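The compounds below may be only part of what the source reports. "The series", "measured", "known", "first", "only" and "open" are said of these compounds alone.

Measured so far:
compound 1 `Fc1ccc(-c2ccc(-c3ccc(-c4nc5ccccc5[nH]4)cc3)cc2)cc1`, 41200 nM
compound 2 `FC(F)(F)c1ccc(-c2ccc(-c3ccc(-c4nc5ccccc5[nH]4)cc3)cc2)cc1`, 45200 nM
compound 3 `Oc1cccc2[nH]c(-c3ccc(-c4ccc(-c5ccc(F)cc5)cc4)cc3)nc12`, 15300 nM

All three were tested in a functional assay on PC-3 cells (Homo sapiens) for inhibition, read by sulforhodamine B assay; on this read-out higher numbers stand for weaker inhibition of growth and lower numbers for stronger inhibition of growth. Compound 4 `Oc1cccc2[nH]c(-c3ccc(-c4ccc(-c5ccc(C(F)(F)F)cc5)cc4)cc3)nc12` remains to be measured.

The change from compound 3 to compound 4 is trifluoromethyl in place of fluoro on an aromatic carbon. The same change, (trifluoromethyl in place of fluoro on an aromatic carbon), has already been made once, giving a 1.1-fold higher number from compound 1 to compound 2 (0.04 log units; within the scatter). The two cores differ by hydroxy in place of hydrogen on an aromatic carbon, a change that by itself gave a 2.7-fold lower number from compound 1 to compound 3 (0.43 log units; beyond the scatter). Among the measured compounds shown here, with only one prior example, and that one within the scatter, a step of similar size is expected here: a 1.1-fold higher number from compound 3 to compound 4 (0.05 log units; within the scatter) is the estimated step, resting on compound 1 and compound 2 showing a 1.1-fold higher number from compound 1 to compound 2 (0.04 log units; within the scatter). Compound 4 is therefore expected to give about 17000 nM, most likely between 8000 nM and 36000 nM.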

Compound 4, concentration for 50% growth inhibition: 2260 nM
Compound 4: middle estimate off by 7.5-fold (0.88 log units), on the high side, and the stated range ends above it.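

In this assay, trifluoromethyl in place of fluoro gives a 6.8-fold lower number from compound 3 to compound 4 (0.83 log units; beyond the scatter), so this change does not carry over unchanged from the core of compound 1 to the hydroxy-bearing core: the same change on two cores in this assay, a 1.1-fold higher number (0.04 log units; within the scatter) from compound 1 to compound 2 and a 6.8-fold lower number (0.83 log units; beyond the scatter) from compound 3 to compound 4, 7.4-fold (0.87 log units) apart, beyond the scatter of two such steps.
Seen from the other side, hydroxy in place of hydrogen gives a 20-fold lower number from compound 2 to compound 4 (1.30 log units; beyond the scatter), and this step also depends on the group it is paired with: the same change on two cores in this assay, a 2.7-fold lower number (0.43 log units; beyond the scatter) from compound 1 to compound 3 and a 20-fold lower number (1.30 log units; beyond the scatter) from compound 2 to compound 4, 7.4-fold (0.87 log units) apart, beyond the scatter of two such steps.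
These four compounds show that the two changes are not independent in this one set, but not how either change behaves on any other core, nor why the steps differ.

The compounds shown leave open whether the larger step needs the hydroxy group itself or would also appear with a methoxy or an amine on the core. Also open, going by these compounds, is whether a chloro or a nitrile in place of trifluoromethyl would behave alike.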